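Benzyl ring substituent exchange in the shared core series

The source may report more compounds than this note shows. Statements on the series, on what has been measured and on what is new or still open speak of the compounds shown alone.

Compound 1 `Cc1cc(Nc2nc(NCc3ccc(Br)cc3)nc3ccccc23)n[nH]1` carries a 4-bromobenzyl arm on the shared core. Going by the values given here, in an assay for inhibition of high affinity nerve growth factor receptor (Homo sapiens), read by HTRF, with a stated time of 30 min, in the presence of a further agent that is not named here (on this read-out higher numbers stand for weaker inhibition and lower numbers for stronger inhibition), compound 1 gives 180 nM, the lowest of the two numbers measured so far. Among the compounds with values here, its only measured neighbour is compound 2 `Cc1cc(Nc2nc(NCc3ccc(C(F)(F)F)cc3)nc3ccccc23)n[nH]1`, which in this assay gives 1400 nM; the step of a 7.8-fold higher number from compound 1 to compound 2 (0.89 log units; beyond the scatter) shows that exchanging the single substituent on this ring shifts the read-out beyond the scatter. Compound 3 `Cc1cc(Nc2nc(NCc3ccc(F)cc3F)nc3ccccc23)n[nH]1` is not yet measured. It differs from compound 1 by 2,4-difluorophenyl in place of 4-bromophenyl on a saturated chain carbon bound to a nitrogen on an aromatic ring. Within the data shown here, only the step from compound 1 to compound 2 bears on this change, and it was modest but beyond the scatter, so a change at the same ring is expected to register again; a step in the same direction, of smaller size, is expected, a 2.5-fold higher number from compound 1 to compound 3 (0.40 log units; beyond the scatter). Compound 3 is therefore estimated at 450 nM in this assay, with a range of 120 nM to 1800 nM.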

Compound 3, half-maximal inhibitory concentration: 200 nM
Compound 3: the middle estimate sits 2.3-fold (0.35 log units) above what was measured; measured number inside the range.
By their numbers in this assay, from the lowest: compounds 1 and 3 (each within the scatter of the next); then compound 2.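

In this assay the exchange of 4-bromophenyl for 2,4-difluorophenyl gives a 1.1-fold higher number from compound 1 to compound 3 (0.05 log units; within the scatter) and so leaves no readable difference at this place. The earlier exchange gave a 7.8-fold higher number from compound 1 to compound 2 (0.89 log units; beyond the scatter) and lay beyond the scatter, so the read-out at this ring does not shift with every substituent exchange: of the two exchanges shown, only trifluoromethyl in place of bromo registers. Nothing measured here bears on why the two exchanges end so differently.

The compounds shown leave open how a nitrile, a methoxy group or an amine on this ring would read against compound 1. They also leave open whether a longer chain in place of the saturated chain carbon would keep the number of compound 1 in this assay or move it.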